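Replacing the Ethylphenyl Tail with Pyridin-2-yl

A few compounds are considered here, and "the series" means these few. Any claim that something is new, unique, unknown or untested is made for them only; others in the source may bear on it.

Compound 1 `CCc1ccc(-c2ccc(NC3=CC(=O)c4ncncc4C3=O)cc2)cc1` gives 1500 nM in a functional assay on MIA PaCa-2 cells (Homo sapiens) for cytotoxicity, read by MTT assay, with a stated time of 72 h (on this read-out lower numbers stand for stronger inhibition and higher numbers for weaker inhibition), the higher of the two numbers measured, though compound 2 `O=C1C(Nc2ccc(C3CCCCC3)cc2)=CC(=O)c2ncncc21` gives 1200 nM and the step of a 1.3-fold lower number from compound 1 to compound 2 (0.10 log units; within the scatter) lies within the scatter. Compound 3 `O=C1C(Nc2ccc(-c3ccccn3)cc2)=CC(=O)c2ncncc21` differs from compound 1 as follows: pyridin-2-yl in place of 4-ethylphenyl on an aromatic carbon. Within the data shown here, the only measured step at this position, a 1.3-fold lower number from compound 1 to compound 2 (0.10 log units; within the scatter), involves a different group and did not move beyond the scatter, so no step bears directly on the new ring. Compound 3 is therefore expected to give 2000 nM, between 700 nM and 6000 nM. That amounts to an estimated step of a 1.3-fold higher number from compound 1 to compound 3 (0.12 log units; within the scatter).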

Compound 3, half-maximal inhibitory concentration: 2000 nM
Beside the measured number, compound 3's estimate shows no gap at the digits printed; low and high end bracket the measured number.
By their numbers in this assay, from the lowest: compounds 2, 1 and 3 (each within the scatter of the next).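

In this assay the step of a 1.3-fold higher number from compound 1 to compound 3 (0.12 log units; within the scatter) and the step of a 1.7-fold higher number from compound 2 to compound 3 (0.22 log units; within the scatter) both stay within the scatter. A ring carrying a nitrogen and one hydrogen-bond acceptor therefore stands at this position without a change beyond the scatter, which the all-carbon groups of compound 1 and compound 2 could not show. Across 4-ethylphenyl, cyclohexyl and pyridin-2-yl, the position has not yet separated the compounds, and no evidence bears on why.

As far as these compounds go, whether an aminomethyl group or a carboxylic acid here would move the number remains open. So does whether pyridin-3-yl would behave as pyridin-2-yl does.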